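Mirror Image of a Stable Lactam: Compound 4

This account rests on a few compounds, and the source may have more. Where it says the series, first, only, none or still open, it means among the compounds named here.

Measured so far:
compound 1, `Cc1ncccc1-c1cnc(NCc2c(F)ccc3c2CCO3)c2nn(CC#N)c(=O)n12`, gives 151 mL.min-1.g-1
compound 2, `C[C@@H]1CC(=O)N(c2cnc(NCc3c(F)ccc4c3CCO4)n3cnnc23)C1`, gives < 3 mL.min-1.g-1
compound 3, `CC(=O)N1CCC(c2cnc(NCc3c(F)ccc4c3CCO4)c3cn[nH]c(=O)c23)CC1`, gives 207 mL.min-1.g-1

The read-out here comes from an ADME assay on microsomes from liver (Homo sapiens) for metabolic stability, read by LC-MS, using NADPH, with stated times of 5 min and 30 min, tested at 1 uM; on this read-out lower numbers stand for slow clearance and higher numbers for fast clearance. Compound 1 and compound 3 both sit high on this scale, which points to fast clearance for each. The value reported for compound 2 is a limit of the assay and not a number. Of the three measurements shown, compound 2 is the one that rests at that edge, as the limit of < 3 mL.min-1.g-1 in this assay, at which 1 of the 3 values shown sits, records, so compound 2 stands at the slow end of what this assay can report.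

The compound to be measured next is compound 4, `C[C@H]1CC(=O)N(c2cnc(NCc3c(F)ccc4c3CCO4)n3cnnc23)C1`. Compared with compound 2, the difference is the two compounds have the same atoms and bonds and differ only in configuration as drawn: 1 of 1 stereo elements differ; a stereocentre at a saturated ring carbon is drawn R in compound 2 and S in compound 4. Nothing is gained or lost in atoms or bonds; only the handedness at one ring carbon is changed. Among the measured compounds shown here, no step between two measured compounds shows what such a change does here, so the expected step from compound 2 to compound 4 in this assay is an at least 1.6-fold higher number from compound 2 to compound 4 (0.22 log units; that floor lies within the scatter), which is taken to be no more than the usual scatter, in no fixed direction. On that basis compound 4 is estimated at 5 mL.min-1.g-1, with a range from 2 mL.min-1.g-1 to 25 mL.min-1.g-1, and a fair chance that this assay again reports only a limit.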

Compound 4, intrinsic clearance in microsomes: < 3 mL.min-1.g-1
Compound 4: a limit, no number; the forecaster's own chance of this, stated with the estimate: 45%; middle value at least 1.6-fold (0.22 log units) from the limit.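

In this assay, among the compounds shown here, compound 2 and compound 4 are each reported only as a limit and not as a number, so no step between them can be read: the limit of < 3 mL.min-1.g-1 in this assay, at which 2 of the 4 values shown sit. The compounds shown leave open how far apart compound 2 and compound 4 lie, and whether the handedness at that saturated ring carbon changes clearance at all.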